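A few compounds are considered here, and "the series" means these few. Any claim that something is new, unique, unknown or untested is made for them only; others in the source may bear on it.

In a functional assay on HEK293 cells (Homo sapiens) for inhibition, read by a luciferase reporter, with a stated time of 24 h (on this read-out lower numbers stand for stronger inhibition and higher numbers for weaker inhibition), compound 1 (`Cc1c(C(=O)Nc2ccccc2)nnn1-c1ccccc1F`) gives 1100 nM, while compound 2 (`Cc1c(C(=O)Nc2ccccc2F)nnn1-c1ccc(C(C)C)cc1`) gives 35 nM. Compound 2 therefore has the lower of the two numbers, meaning stronger inhibition, and the gap is beyond the scatter. Compound 3 (`Cc1c(C(=O)Nc2cccc(F)c2)nnn1-c1ccc(C(C)C)cc1`) has 3-fluorophenyl in place of 2-fluorophenyl on an amide-type nitrogen. Among the compounds with values here, no measured pair shows this kind of change, so the expectation in this assay is only a small drift toward a higher number, not clearly beyond the scatter. The expected step is a 1.7-fold higher number from compound 2 to compound 3 (0.23 log units; within the scatter). The estimate for compound 3 is 60 nM, with a range of 20 nM to 200 nM.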

Compound 3, half-maximal inhibitory concentration: 13 nM
Compound 3: the middle estimate sits 4.6-fold (0.66 log units) above what was measured, and the stated range ends above it.
By their numbers in this assay, from the lowest: compound 3; then compound 2; then compound 1.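

Putting 3-fluorophenyl in place of 2-fluorophenyl on the amide-type nitrogen keeps the same atoms, yet in this assay it gives a 2.7-fold lower number from compound 2 to compound 3 (0.43 log units; beyond the scatter) and this modest step lies beyond the scatter. Within the data shown here, compound 1 and compound 2 differ in more than one place, so this is the first direct sign that this position responds to where the fluorine sits on the phenyl ring. Nothing shown here explains the step.

Still open, as far as these compounds go, is whether 3-chlorophenyl or 3-methoxyphenyl at this position would give a lower or a higher number. Also open, from the compounds shown here alone, is whether 4-fluorophenyl would do the same as 3-fluorophenyl.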